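Methyl for chloro on a fused quinazoline-free core series

A few compounds are considered here, and "the series" means these few. Any claim that something is new, unique, unknown or untested is made for them only; others in the source may bear on it.

Compound 1 `CC(C)Nc1nc(NCc2ccco2)c2cc(Cl)ccc2n1` gives 1630 10^-6 cm/s.
Compound 2 `CC(C)Nc1nc(NCc2ccco2)c2c(Cl)cccc2n1` gives 1240 10^-6 cm/s.
Compound 3 `Cc1ccc2nc(NC(C)C)nc(NCc3ccco3)c2c1` gives 789 10^-6 cm/s.

Three compounds were measured in a physicochemical assay for permeability, using PAMPA, at pH 7.4; a lower number here means that the compound crosses the layer more slowly, a higher number that the compound crosses the layer faster. Compound 1 and compound 2 share the same atoms joined differently; the difference between the two cores is not broken down here. Their values lie within the scatter of each other, as do those of compound 2 and compound 3. Among the measured compounds shown here, the one counted change, (methyl in place of chloro on an aromatic carbon), gave a 2.1-fold lower number from compound 1 to compound 3 (0.32 log units; beyond the scatter).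

Compound 4 `Cc1cccc2nc(NC(C)C)nc(NCc3ccco3)c12` has not yet been measured in this assay. It differs from compound 2 by methyl in place of chloro on an aromatic carbon. This is the same kind of change as from compound 1 to compound 3, though at a different place: there the methyl stands meta to a fused ring and para to a fused ring, here ortho to a fused ring and meta to a fused ring. Resting on compound 1 and a 2.1-fold lower number from compound 1 to compound 3 (0.32 log units; beyond the scatter), the step from compound 2 to compound 4 is expected to be a 2.1-fold lower number from compound 2 to compound 4 (0.32 log units; beyond the scatter). Compound 4 is estimated at 600 10^-6 cm/s, between 350 10^-6 cm/s and 1000 10^-6 cm/s.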

Compound 4, apparent permeability: 812 10^-6 cm/s
Beside the measured number, compound 4's estimate is 1.4-fold (0.13 log units) below it; low and high end bracket the measured number.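

In this assay, methyl in place of chloro at the second place gave a 1.5-fold lower number from compound 2 to compound 4 (0.18 log units; within the scatter), whereas the same kind of change at the first place gave a 2.1-fold lower number from compound 1 to compound 3 (0.32 log units; beyond the scatter). The step beyond the scatter in the first pair therefore has no counterpart beyond the scatter in the second pair, so a reading taken from one arrangement of the shared core cannot be assumed to carry over in full to the other, although these two pairs alone do not show how much the position matters or establish any general rule for the series. Nothing in the data presented here explains why the two pairs read as they do.

The compounds shown leave open how a fluoro, a methoxy or an amine in place of chloro would read at either place. They also leave open whether such groups would follow the pair of compound 1 and compound 3 or the pair of compound 2 and compound 4.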